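A few compounds are considered here, and "the series" means these few. Any claim that something is new, unique, unknown or untested is made for them only; others in the source may bear on it.

Measured compounds in a functional assay on CHO cells for antagonist activity at Orexin receptor type 2 (Homo sapiens), read by FLIPR and calcium flux; a lower number here means a stronger inhibitor, a higher number a weaker inhibitor: compound 1 `CNC(=O)[C@@H](c1ccccc1)N1CCn2c(COC)nc(Cl)c2[C@@H]1CCc1ccc(C(F)(F)F)cc1` gives 25 nM; compound 2 `CCc1nc(C(C)C)c2n1CCN([C@@H](C(=O)NC)c1ccccc1)C2CCc1ccc(C(F)(F)F)cc1` gives 2900 nM; compound 3 `CCc1nc(C(=O)N(C)C)c2n1CCN([C@@H](C(=O)NC)c1ccccc1)C2CCc1ccc(C(F)(F)F)cc1` gives 111 nM.

Compound 2 stands highest of the three numbers; compound 3 is nearest to it and compound 1 furthest. Among the compounds with values here, the only step at the same aromatic carbon is a 26-fold lower number from compound 2 to compound 3 (1.42 log units; beyond the scatter), a large drop. Compound 4 `CCc1nc(C)c2n1CCN([C@@H](C(=O)NC)c1ccccc1)C2CCc1ccc(C(F)(F)F)cc1` carries the change (methyl in place of isopropyl on an aromatic carbon), methyl in place of isopropyl on an aromatic carbon. Within the data shown here, no measured pair shows a methyl at this carbon, so the estimate rests on that single step. Expected is a moderate drop from compound 2, a 3.6-fold lower number from compound 2 to compound 4 (0.56 log units; beyond the scatter), smaller than the drop seen in compound 3, with wide uncertainty. Compound 4 is estimated at 800 nM, within 250 nM to 2500 nM in this assay.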

Compound 4, half-maximal inhibitory concentration: 24 nM
Beside the measured number, compound 4's estimate is 33-fold (1.52 log units) above it, outside the stated range (below it).
By their numbers in this assay, from the lowest: compounds 4 and 1 (each within the scatter of the next); then compound 3; then compound 2.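

At this aromatic carbon, this assay shows a 120-fold lower number from compound 2 to compound 4 (2.08 log units; beyond the scatter), so the isopropyl group, not the shared core, accounts for the weak number of compound 2. Methyl also improves on dimethylcarbamoyl, with a 4.6-fold lower number from compound 3 to compound 4 (0.67 log units; beyond the scatter), so the carbonyl-bearing group is not needed for a low number here, and isopropyl is the weakest of the three groups at this carbon. No evidence on the origin of these steps is available.

Open, from the compounds shown here alone, is how an ethyl or cyclopropyl group at this carbon would read, and with it where between methyl and isopropyl the loss sets in.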